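The source may report more compounds than this note shows. Statements on the series, on what has been measured and on what is new or still open speak of the compounds shown alone.

Compound 1 `COC(=O)[C@@]1(C)CCC=C2[C@@H]1CC[C@@H](C)[C@]2(C)Cc1c(C)[nH]c2ccccc12` gives 17000 nM in a functional assay on T47D cells (Homo sapiens) for inhibition, read by sulforhodamine B assay, with a stated time of 48 h; on this read-out lower numbers stand for stronger inhibition of growth and higher numbers for weaker inhibition of growth.
Compound 2 `COC(=O)[C@@]1(C)CCC=C2[C@@H]1CC[C@@H](C)[C@]2(C)Cc1c(C)[nH]c2ccc(C)cc12` gives 31000 nM in this assay.
Compound 3 `COC(=O)[C@@]1(C)CCC=C2[C@@H]1CC[C@@H](C)[C@]2(C)Cc1c(C)[nH]c2ccc(OC)cc12` gives 15000 nM in this assay.

Among these three numbers compound 3 sits alongside compound 1, the two being separated only by a 1.1-fold lower number from compound 1 to compound 3 (0.05 log units; within the scatter), while the step of a 2.1-fold lower number from compound 2 to compound 3 (0.32 log units; beyond the scatter) sets it apart from compound 2 by a modest margin. The whole series thus spans a narrow band in this assay.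

Compound 4 `COC(=O)[C@@]1(C)CCC=C2[C@@H]1CC[C@@H](C)[C@]2(C)Cc1c(C)[nH]c2ccc(C(F)(F)F)cc12` differs from compound 3 in one place: trifluoromethyl in place of methoxy on an aromatic carbon. No measured step involves a trifluoromethyl group, so the expectation rests on what the same aromatic position has shown so far. Replacing hydrogen there by methyl gave a 1.8-fold higher number from compound 1 to compound 2 (0.26 log units; within the scatter), replacing hydrogen by methoxy gave a 1.1-fold lower number from compound 1 to compound 3 (0.05 log units; within the scatter), and the change from methyl to methoxy gave a 2.1-fold lower number from compound 2 to compound 3 (0.32 log units; beyond the scatter). All three substituents at this position keep the number within or barely beyond the usual scatter of one another. Compound 4 is therefore expected to show a 1.5-fold higher number from compound 3 to compound 4 (0.17 log units; within the scatter), a step of no more than modest size, if anything toward a higher number, since the one substituent without an acceptor, in compound 2, gave 31000 nM. The estimate for compound 4 in this assay is 22000 nM, with a range from 8000 nM to 60000 nM.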

Compound 4, concentration for 50% growth inhibition: 21000 nM
The estimate for compound 4 lay 1.0-fold (0.02 log units) above the measured number; the measured number falls inside the stated range.
By their numbers in this assay, from the lowest: compounds 3, 1, 4 and 2 (each within the scatter of the next, the first and the last beyond it).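

In this assay, trifluoromethyl on this aromatic carbon stays within the scatter of all three earlier compounds, with a 1.2-fold higher number from compound 1 to compound 4 (0.09 log units; within the scatter), a 1.4-fold higher number from compound 3 to compound 4 (0.15 log units; within the scatter) and a 1.5-fold lower number from compound 2 to compound 4 (0.17 log units; within the scatter). The earlier compounds shown here left one question unsettled: methoxy, which carries a hydrogen-bond acceptor, was set apart from methyl, which carries none, by a 2.1-fold lower number from compound 2 to compound 3 (0.32 log units; beyond the scatter), but trifluoromethyl also counts no acceptor and still lies within the scatter of both, so the presence of an acceptor does not sort these values. Nothing measured here accounts for how little the number moves across these four compounds at this place.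

The compounds shown leave open whether an amine or a carboxylic acid on this same aromatic carbon would take the number outside this narrow band, or whether this place simply tolerates whatever is put there. They also leave open whether the same flat picture would hold if a carboxylic acid replaced the methyl ester of the shared core, a change that might reveal a stronger dependence on the substituent.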